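The source may report more compounds than this note shows. Statements on the series, on what has been measured and on what is new or still open speak of the compounds shown alone.

Series notes, three compounds measured in an assay on HEK293 cells for inhibition of Voltage-dependent N-type calcium channel subunit alpha-1B (Homo sapiens), read by fluorescence and calcium flux, with a stated time of 5 min; a higher number here means a weaker inhibitor, a lower number a stronger inhibitor. Compound 2 `COc1ccccc1-n1nc([C@@H]2CCO[C@@H](C(C)C)C2)cc1-c1ccc(Cl)cc1` gives 20 nM, the highest of the three numbers; compound 1 `COc1ccccc1-n1nc(C2CC(C)(C)OC(C)(C)C2)cc1-c1ccc(C)nc1` gives 6 nM and compound 3 `CCOc1ccc(-c2cc(C3CC(C)(C)OC(C)(C)C3)nn2-c2ccccc2OC)cc1` gives 2 nM. Going by the values given here, the one single-point step measured so far, a 3.0-fold lower number from compound 1 to compound 3 (0.48 log units; beyond the scatter), concerns the aryl group and not the saturated ring, so nothing measured bears directly on the change to compound 4 `COc1ccccc1-n1nc([C@H]2C[C@@H](C)O[C@@H](C)C2)cc1-c1ccc(Cl)cc1`, which is 2,6-dimethyloxan-4-yl in place of 2-isopropyloxan-4-yl on an aromatic carbon. Compounds 1 and 3 carry a more substituted ring at that place and sit lower than compound 2, so a small movement toward them is expected, a 1.3-fold lower number from compound 2 to compound 4 (0.12 log units; within the scatter), not clearly beyond the scatter. Compound 4 is therefore estimated at 15 nM, range 5 nM to 45 nM.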

Compound 4, half-maximal inhibitory concentration: 3 nM
The estimate for compound 4 lay 5.0-fold (0.70 log units) above the measured number; the measured number lies below the stated range.
By their numbers in this assay, from the lowest: compounds 3, 4 and 1 (each within the scatter of the next, the first and the last beyond it); then compound 2.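

In this assay, the substituents on the saturated oxane ring matter at this place on the shared core: 2,6-dimethyloxan-4-yl in place of 2-isopropyloxan-4-yl gives a 6.7-fold lower number from compound 2 to compound 4 (0.82 log units; beyond the scatter) with the two aryl groups unchanged. This single pair cannot separate the loss of isopropyl from the gain of two methyl groups and the extra defined stereocentre. Nothing available gives a reason for the step.

Still open, as far as these compounds go, is whether a single methyl, an ethyl or an amine on this ring would match compound 4. From the compounds shown here alone, how the other stereoisomers of compound 4 read also remains open.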